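The source may report more compounds than this note shows. Statements on the series, on what has been measured and on what is new or still open speak of the compounds shown alone.

Three compounds share one core and differ only in the group attached to the aromatic carbon next to the ring nitrogen. Compound 1 `C[C@]1(CN2CCc3nc(-c4ccccc4)ccc3C2)Cn2cc([N+](=O)[O-])nc2O1` carries a phenyl there. In an ADME assay on Vero cells (Chlorocebus sabaeus) for cytotoxicity, read by MTT assay, with a stated time of 72 h (a higher number here means that more compound is tolerated, a lower number that less compound is tolerated), compound 1 reaches only a limit, > 32 ug/mL, as noted in the limit of > 32 ug/mL in this assay, at which 1 of the 3 values shown sits. Compound 2 `C[C@]1(CN2CCc3nc(N4CCCCC4)ccc3C2)Cn2cc([N+](=O)[O-])nc2O1` carries a piperidine ring; in this assay compound 2 gives "not determined" (no result reported). Compound 3 `C[C@]1(CN2CCc3nc(-c4ccc(C#N)cc4)ccc3C2)Cn2cc([N+](=O)[O-])nc2O1` carries a 4-cyanophenyl, and in this assay compound 3 gives "not determined" (no result reported), so no single number places it on the scale. Compound 4 `C[C@]1(CN2CCc3nc(-c4ccc(F)c(F)c4)ccc3C2)Cn2cc([N+](=O)[O-])nc2O1` brings the change (3,4-difluorophenyl in place of 4-cyanophenyl on an aromatic carbon). For the measured compounds named here, with no measured step to lean on, compound 4 is expected to behave like compound 1, and its value in this assay is estimated at 32 ug/mL, within 16 ug/mL to 64 ug/mL.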

Compound 4, half-maximal cytotoxic concentration: > 32 ug/mL
Compound 4: a limit, no number; the forecaster's own chance of this, stated with the estimate: 75%; the middle value sits exactly at the limit.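

Compound 1 and compound 4 both stop at a limit in this assay, so no step between them can be read: the limit of > 32 ug/mL in this assay, at which 2 of the 4 values shown sit.

The compounds shown leave open the concentration at which any of them actually harms the cells, and whether changing the group shifts it.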